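The source may hold more compounds than are shown below. What is called first, only, known or untested is meant among the compounds shown, and "the series" means these compounds.

Measured so far in a functional assay on A2780 cells (Homo sapiens) for inhibition; a lower number here means a stronger inhibitor, a higher number a weaker inhibitor:
Compound 1 `C=CNCc1cc(-c2c(C(=O)NCC)noc2-c2cc(C(C)C)c(O)cc2O)on1` gives 43 nM
Compound 2 `CCNC(=O)c1noc(-c2cc(C(C)C)c(O)cc2O)c1-c1cc(CNC(C)=O)no1` gives "not determined" (no result reported)
Compound 3 `CCNC(=O)c1noc(-c2cc(C(C)C)c(O)cc2O)c1-c1cc(CN2CCCC2)no1` gives 55 nM

Compound 2 has no number in this assay, so the step to compound 4 `CCNC(=O)c1noc(-c2cc(C(C)C)c(O)cc2O)c1-c1cc[nH]n1` has no measured starting point. The structural change is 1H-pyrazol-3-yl in place of 3-(acetamidomethyl)-1,2-oxazol-5-yl on an aromatic carbon, which places 1H-pyrazol-3-yl on the aromatic carbon that carried 3-(acetamidomethyl)-1,2-oxazol-5-yl in compound 2.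

Going by the values given here, only one measured step exists, a 1.3-fold higher number from compound 1 to compound 3 (0.11 log units; within the scatter). It lies within the scatter, and it alters only the group on the saturated chain carbon. It does not remove the ring that is exchanged here, so it bears on this change only indirectly. It does suggest that the outer part of this substituent can vary without a clear shift, but the data do not show what happens when the whole substituent is replaced. No direction can therefore be given, and a step of unknown size remains possible. The expectation rests on compound 1 at 43 nM and compound 3 at 55 nM. Compound 4 is expected at about 45 nM, within an estimated range of 14 nM to 150 nM.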

Compound 4, half-maximal inhibitory concentration: 33 nM
For compound 4 the middle estimate is 1.4-fold (0.13 log units) above the measured one, within the range that was stated.
By their numbers in this assay, from the lowest: compounds 4, 1 and 3 (each within the scatter of the next).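

In this assay, the change at this aromatic carbon goes beyond the earlier variation of the group on the saturated chain carbon: the whole 3-((vinylamino)methyl)-1,2-oxazol-5-yl substituent gives way to 1H-pyrazol-3-yl, with 5 heavy atoms, and the result is a 1.3-fold lower number from compound 1 to compound 4 (0.11 log units; within the scatter), so neither that oxazole ring nor its side chain is shown to be needed for a number in this range. The step from compound 2 cannot be read, which leaves the exchange of 3-(acetamidomethyl)-1,2-oxazol-5-yl itself without a size. Nothing available explains why the numbers stay so close.

The compounds shown leave open whether any ring is needed on this carbon, as a plain hydrogen or a methyl group there would show. They also leave open how a phenyl ring, or a pyrazole carrying a methyl group on its nitrogen, would compare with compound 4.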